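A Chlorine Added to the Benzyl Group of Compound 2

A few compounds are considered here, and "the series" means these few. Any claim that something is new, unique, unknown or untested is made for them only; others in the source may bear on it.

Three measured compounds share one core. Compound 1 `CC(C)(C)CNC(=O)C[C@H](NC(=O)CN1CCCCC1)C(=O)N[C@@H](CCc1ccccc1)C(=O)NCc1ccccc1` gives 62 nM in an assay on HEK293 cells for inhibition of nuclear factor NF-kappa-B complex (Homo sapiens), read by a luciferase reporter, with stated times of 1 h and 3 h; a higher number here means a weaker inhibitor, a lower number a stronger inhibitor; compound 2 `CC(C)(C)CNC(=O)C[C@H](NC(=O)CCc1ccccc1)C(=O)N[C@@H](CCc1ccccc1)C(=O)NCc1ccccc1` gives 12 nM, the lowest of the three; compound 3 `CC(C)(C)CNC(=O)C[C@H](NC(=O)c1ccc(C(C)(C)C)cc1)C(=O)N[C@@H](CCc1ccccc1)C(=O)NCc1ccccc1` gives 32 nM. The steps of a 5.2-fold lower number from compound 1 to compound 2 (0.71 log units; beyond the scatter) and a 2.7-fold higher number from compound 2 to compound 3 (0.43 log units; beyond the scatter) both change the group on the carbonyl carbon that caps the chain, leaving the benzyl group untouched. Compound 4 `CC(C)(C)CNC(=O)C[C@H](NC(=O)CCc1ccccc1)C(=O)N[C@@H](CCc1ccccc1)C(=O)NCc1ccccc1Cl` differs from compound 2 at that benzyl group instead: chloro in place of hydrogen on an aromatic carbon. Going by the values given here, no measured step touches this ring, so the data give no guide to its effect, and a change no larger than the scatter is expected, no change at the digits printed from compound 2 to compound 4 (within the scatter). Compound 4 is estimated at 12 nM, within a range from 4 nM to 36 nM.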

Compound 4, half-maximal inhibitory concentration: 18 nM
The estimate for compound 4 lay 1.5-fold (0.18 log units) below the measured number; the measured number falls inside the stated range.
By their numbers in this assay, from the lowest: compounds 2, 4, 3 and 1 (each within the scatter of the next, the first and the last beyond it).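

Placing a chloro group on the benzyl ring, ortho to a large group, gives a 1.5-fold higher number from compound 2 to compound 4 (0.18 log units; within the scatter). Going by these compounds alone, this is the first measured change to this ring, and it shows that the 2-chlorobenzyl compound stays within the scatter of the benzyl compound, so this single added atom leaves the number essentially where it was. No evidence is available to explain this result. The compounds shown leave open how this ring responds to a different group, such as methoxy, an amine or a carboxylic acid. They also leave open whether chloro elsewhere on the ring behaves the same way.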